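This account rests on a few compounds, and the source may have more. Where it says the series, first, only, none or still open, it means among the compounds named here.

In an ADME assay on the whole organism (strain CD-1) for metabolic stability, with Mus musculus as the target, at a dose of 50 mg/kg by the oral route (on this read-out higher numbers stand for a longer-lived compound and lower numbers for a shorter-lived compound), three compounds sharing much of their structure have been measured. Compound 1 `O=C(N[C@@H]1C[C@@H](C(=O)NC[C@@H]2CC(Br)=NO2)N(C(=O)OCc2cnc3ccccc3c2)C1)c1cccnc1` gives 0.25 h, compound 2 `O=C(N[C@@H]1C[C@@H](C(=O)NC[C@@H]2CC(Br)=NO2)N(C(=O)OCc2cnc3ccccc3c2)C1)c1ccc(O)cc1` gives 0.25 h, and compound 3 `O=C(NC[C@@H]1CC(Br)=NO1)[C@@H]1C[C@@H](OCc2ccccc2)CN1C(=O)OCc1cnc2ccccc2c1` gives 0.25 h, so compound 3 stands level with the other two. The next compound to be measured is compound 4 `O=C(NC[C@@H]1CC(Br)=NO1)[C@@H]1C[C@@H](O)CN1C(=O)OCc1cnc2ccccc2c1`, which differs from compound 3 by a single change: hydrogen in place of benzyl on an oxygen on a saturated carbon. This is hydrogen in place of benzyl on an oxygen on a saturated carbon, so benzyloxy becomes hydroxy. Two measured steps bring in the benzyloxy group in place of a larger amide-bearing group, and they show no change at the digits printed from compound 1 to compound 3 (within the scatter) and no change at the digits printed from compound 2 to compound 3 (within the scatter). A third step, made at a carbonyl carbon, shows no change at the digits printed from compound 1 to compound 2 (within the scatter). Within the data shown here, none of the three moves the half-life, although no measured compound carries the hydroxy group, so the evidence is indirect. No shift beyond the scatter is therefore expected in this assay, and the expected step is no change at the digits printed from compound 3 to compound 4 (within the scatter). For compound 4 the estimated value is 0.25 h, with an expected range of 0.12 h to 0.6 h.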

Compound 4, half-life: 0.25 h
Compound 4: the middle estimate sits on the measured number at the digits printed, within the range that was stated.
By their numbers in this assay, from the lowest: compounds 1, 2, 3 and 4 (each within the scatter of the next).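

In this assay, taking the benzyl off the oxygen turns benzyloxy into hydroxy and gives no change at the digits printed from compound 3 to compound 4 (within the scatter), so this position has now been tested without any aromatic ring on that oxygen. Among these compounds, replacing the amide-bearing groups of the earlier compounds with the same hydroxy gives no change at the digits printed from compound 2 to compound 4 (within the scatter) and no change at the digits printed from compound 1 to compound 4 (within the scatter). All four groups seen on this saturated ring carbon therefore give the same half-life at the digits printed, and no supporting measurement speaks to the reason.

As far as these compounds go, whether an amine or a carboxylic acid on this carbon would separate from these compounds remains open. Also open, from the compounds shown here alone, is whether a change elsewhere in the shared core would move the half-life, as all four compounds differ only at this position.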